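A few compounds are considered here, and "the series" means these few. Any claim that something is new, unique, unknown or untested is made for them only; others in the source may bear on it.

Compound 1 `COc1ccc(NC(=O)c2cc(Oc3ccc(/C=C/c4ccncc4)cc3)ccn2)cc1` in a functional assay on HepG2 cells (Homo sapiens) for antiproliferative activity, read by CCK-8 assay, with a stated time of 48 h (a higher number here means a weaker inhibitor, a lower number a stronger inhibitor), gives a limit rather than a number: > 100000 nM.
Compound 2 `O=C(NCc1ccc(F)cc1)c1cc(Oc2ccc(/C=C/c3ccncc3)cc2)ccn1` gives 37200 nM.

Compound 2 thus holds the only plain number among the two results shown; the other result is a limit (the limit of > 100000 nM in this assay, at which 1 of the 2 values shown sits). The step to compound 3 `CC(C)NC(=O)c1cc(Oc2ccc(/C=C/c3ccncc3)cc2)ccn1` changes the group on the amide-type nitrogen (isopropyl in place of 4-fluorobenzyl on an amide-type nitrogen). Among the compounds with values here, the single measured step, an at least 2.6-fold lower number from compound 1 to compound 2 (0.42 log units; beyond the scatter), changed the same position and moved the number downward beyond the scatter. That step did not involve isopropyl, so it shows only that this position can move the result, not where isopropyl will land. For compound 3 a change of modest size, near the edge of the scatter, is expected: a 1.3-fold higher number from compound 2 to compound 3 (0.13 log units; within the scatter). Compound 3 is therefore estimated at 50000 nM, with a range from 15000 nM to 150000 nM.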

Compound 3, half-maximal inhibitory concentration: 33700 nM
The estimate for compound 3 lay 1.5-fold (0.17 log units) above the measured number; low and high end bracket the measured number.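

Compound 2 and compound 3 carry very different groups on the amide-type nitrogen, one with a six-membered aromatic ring and a fluorine and one with neither, yet the swap gives a 1.1-fold lower number from compound 2 to compound 3 (0.04 log units; within the scatter). The ring of 4-fluorobenzyl is therefore not needed to hold the result at this level, at least when isopropyl replaces it. Isopropyl in place of 4-methoxyphenyl gives an at least 2.9-fold lower number from compound 1 to compound 3 (0.47 log units; beyond the scatter), so a second group, this one without a ring, also lies on the lower side of the step seen earlier at this position.

Going by these compounds, whether a longer chain, or one ending in an amine or a carboxylic acid, would move the number beyond the scatter stays open. The full size of both steps from compound 1 also stays open, because its value is a limit: the limit of > 100000 nM in this assay, at which 1 of the 3 values shown sits.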